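The source may report more compounds than this note shows. Statements on the series, on what has been measured and on what is new or still open speak of the compounds shown alone.

In an assay on membranes from spleen (Cavia porcellus) for binding affinity to leukotriene B4 receptor 1 (Homo sapiens) (on this read-out higher numbers stand for weaker inhibition and lower numbers for stronger inhibition), three compounds have been measured so far. Compound 1 `CC(C)(CCCCOc1cc(-c2ccc(Cl)cc2)c2ccccc2n1)C(=O)O` gives 15 nM, compound 2 `CC(C)(CCCCOc1cc(-c2ccc([N+](=O)[O-])cc2)c2ccccc2n1)C(=O)O` gives 150 nM, and compound 3 `CC(C)(CCCCOc1cc(-c2ccc(N)cc2)c2ccccc2n1)C(=O)O` gives 40 nM, which places compound 3 second highest of the three numbers, nearer to compound 1 than to compound 2. Putting nitro in place of chloro gives a 10-fold higher number from compound 1 to compound 2 (1.00 log units; beyond the scatter), putting amino in place of chloro gives a 2.7-fold higher number from compound 1 to compound 3 (0.43 log units; beyond the scatter), and putting amino in place of nitro gives a 3.8-fold lower number from compound 2 to compound 3 (0.57 log units; beyond the scatter). Compound 4 `COc1cccc(-c2cc(OCCCCC(C)(C)C(=O)O)nc3ccccc23)c1` has not been measured yet; it differs from compound 3 by 3-methoxyphenyl in place of 4-aminophenyl on an aromatic carbon. For the measured compounds named here, none of the measured steps covers this exact exchange, since each of them swaps one substituent on the phenyl group for another at the same place, whereas compound 4 carries a different substituent altogether. What those steps do show is that changes on this phenyl group move this assay modestly. Compound 4 is therefore expected to land near compound 3, the expected step being no change at the digits printed from compound 3 to compound 4 (within the scatter), with no firm direction beyond the scatter. Compound 4 is estimated at 40 nM, with a range from 10 nM to 160 nM.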

Compound 4, half-maximal inhibitory concentration: 300 nM
The estimate for compound 4 lay 7.5-fold (0.88 log units) below the measured number; the measured number lies above the stated range.
By their numbers in this assay, from the lowest: compound 1; then compound 3; then compounds 2 and 4 (each within the scatter of the next).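

In this assay, for the compounds shown here, exchanging the whole phenyl group can move the number further than the earlier swaps of one substituent did: 3-methoxyphenyl in place of 4-chlorophenyl gives the only large step so far (a 20-fold higher number from compound 1 to compound 4 (1.30 log units; beyond the scatter)). 3-Methoxyphenyl in place of 4-aminophenyl also costs clearly (a 7.5-fold higher number from compound 3 to compound 4 (0.88 log units; beyond the scatter)), so this position accepts 4-chlorophenyl and 4-aminophenyl better than 3-methoxyphenyl. Against 4-nitrophenyl the exchange gives no separation (a 2.0-fold higher number from compound 2 to compound 4 (0.30 log units; within the scatter)), so 3-methoxyphenyl and 4-nitrophenyl cannot be told apart here.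

Compound 4 changes both the substituent and its place on the phenyl group, so 4-methoxyphenyl and 3-chlorophenyl are the groups that would show which of the two changes carries the effect. Nothing measured here gives a reason for the result.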